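From compound 3 to compound 4: one group exchanged

The compounds below may be only part of what the source reports. "The series", "measured", "known", "first", "only" and "open" are said of these compounds alone.

Measured in a physicochemical assay for lipophilicity, using the shake flask method, in phosphate buffer, measured as octanol-water partition, with a stated time of 30 min, at pH 7.4; on this read-out higher numbers stand for higher lipophilicity and lower numbers for lower lipophilicity:
- compound 1 `O=C1c2ccccc2CN1c1cnc(NCc2c(F)ccc3c2CCO3)n2cnnc12`: 2.7
- compound 2 `CN(c1ccn(C)n1)c1cnc(NCc2c(F)ccc3c2CCO3)n2cnnc12`: 1.8
- compound 3 `O=C(Nc1cnc(NCc2c(F)ccc3c2CCO3)n2cnnc12)c1cccnc1`: 2

Of these three numbers, the highest belongs to compound 1. The series shows a number 0.70 log units lower from compound 1 to compound 3 (beyond the scatter), and it also shows a number 0.20 log units higher from compound 2 to compound 3 (within the scatter). Compound 3 therefore sits in the lower pair, level with its nearest neighbour.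

Compound 4 `CN(c1cccnc1)c1cnc(NCc2c(F)ccc3c2CCO3)n2cnnc12` carries methyl(pyridin-3-yl)amino in place of ((pyridin-3-yl)carbonyl)amino on an aromatic carbon. Among the measured compounds shown here, no measured step makes exactly this exchange. The closest is a number 0.20 log units higher from compound 2 to compound 3 (within the scatter), which links the leaving group to methyl(1-methyl-1H-pyrazol-3-yl)amino, the measured group most like the entering one. The larger steps, a number 0.90 log units lower from compound 1 to compound 2 (beyond the scatter) and a number 0.70 log units lower from compound 1 to compound 3 (beyond the scatter), start from a group found in neither compound 3 nor compound 4, so they say little about this exchange.

On the evidence of that closest step, no change beyond the scatter is expected in this assay, though a small rise is possible. The expected step is a number 0.20 log units higher from compound 3 to compound 4 (within the scatter). For compound 4 the estimated value is 2.2, with an expected range from 1.8 to 2.7.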

Compound 4, distribution coefficient: 2.6
For compound 4 the middle estimate is 0.40 log units below the measured one; measured number inside the range.
By their numbers in this assay, from the lowest: compounds 2 and 3 (each within the scatter of the next); then compounds 4 and 1 (each within the scatter of the next).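

At this aromatic carbon of the shared core, this assay gives a number 0.60 log units higher from compound 3 to compound 4 (beyond the scatter) with the six-membered aromatic ring kept, so the exchange of ((pyridin-3-yl)carbonyl)amino for methyl(pyridin-3-yl)amino, which removes the carbonyl and the amide hydrogen, is itself enough to move the read-out beyond the scatter. Among the compounds shown here, with the methylated nitrogen held constant, the attached ring also counts, as pyridin-3-yl in place of 1-methyl-1H-pyrazol-3-yl gives a number 0.80 log units higher from compound 2 to compound 4 (beyond the scatter) and thereby separates a ring effect from the exchange at the nitrogen, which the earlier steps could not do. The smaller methyl(pyridin-3-yl)amino group, which carries no second ring, also stays within the scatter of the fused group of compound 1, as a number 0.10 log units lower from compound 1 to compound 4 (within the scatter) shows in this assay.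

Nothing given here explains any of these steps. As far as these compounds go, it also remains open whether a methylated amide, which would keep the carbonyl but lose the amide hydrogen, or a saturated amine such as morpholine at this carbon would follow the same course.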